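Notes on the alkyl substituent series at the chain carbon

The source may hold more compounds than are shown below. What is called first, only, known or untested is meant among the compounds shown, and "the series" means these compounds.

Measured so far:
compound 1 `Cn1c([C@H](CC2CCCCC2)N2C(=O)CN(c3ccc(Oc4ccccc4)cc3)C2=O)nc2ccc(C(=O)O)cc21`: 24400 nM
compound 2 `CC[C@@H](c1nc2ccc(C(=O)O)cc2n1C)N1C(=O)CN(c2ccc(Oc3ccccc3)cc2)C1=O`: 210000 nM
compound 3 `C[C@@H](c1nc2ccc(C(=O)O)cc2n1C)N1C(=O)CN(c2ccc(Oc3ccccc3)cc2)C1=O`: 10400 nM

In an assay on isolated protein for inhibition of Bile acid receptor (Homo sapiens), read by TR-FRET and LanthaScreen (on this read-out higher numbers stand for weaker inhibition and lower numbers for stronger inhibition), compound 3 holds the lowest number of the three; compound 1 is the nearest, and compound 2 the furthest, both beyond the scatter from compound 3. The unmeasured compound 4 `Cn1c([C@@H](N2C(=O)CN(c3ccc(Oc4ccccc4)cc3)C2=O)C(C)(C)C)nc2ccc(C(=O)O)cc21` differs from compound 3 by one change: tert-butyl in place of methyl on a saturated chain carbon bound to an amide-type nitrogen in a ring and an aromatic carbon.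

For the measured compounds named here, two measured steps bear on the change, both at the same carbon. Enlarging the group there from hydrogen to methyl gave a 20-fold lower number from compound 2 to compound 3 (1.31 log units; beyond the scatter) read backwards, and from hydrogen to cyclohexyl gave a 2.3-fold lower number from compound 1 to compound 3 (0.37 log units; beyond the scatter) read backwards; in both cases the larger group carries the higher number, though the two sizes of effect differ widely, and compound 1 does not follow a simple size order against compound 2. A tert-butyl group is larger again than either substituent tested, so a higher number than compound 3 in this assay is expected for compound 4, likely between the two measured steps in size, with considerable uncertainty. Compound 4 is estimated at 60000 nM, with a range of 15000 nM to 250000 nM, which is an expected step of a 5.8-fold higher number from compound 3 to compound 4 (0.76 log units; beyond the scatter) from compound 3.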

Compound 4, half-maximal inhibitory concentration: 77100 nM
For compound 4 the middle estimate is 1.3-fold (0.11 log units) below the measured one, and the stated range covers the measured number.
By their numbers in this assay, from the lowest: compound 3; then compound 1; then compound 4; then compound 2.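

In this assay the step to a branched group is upward (  a 7.4-fold higher number from compound 3 to compound 4 (0.87 log units; beyond the scatter)), so methyl on this saturated chain carbon keeps the lowest number of the four against tert-butyl as well as against ethyl and cyclohexylmethyl, each of those gaps lying beyond the scatter. The order does not simply follow the size of the substituent, since tert-butyl in place of ethyl lowers the number (a 2.7-fold lower number from compound 2 to compound 4 (0.44 log units; beyond the scatter)) and the highest number of the four therefore belongs to ethyl, which goes against any steady rise with size. Cyclohexylmethyl also stands lower than tert-butyl (a 3.2-fold higher number from compound 1 to compound 4 (0.50 log units; beyond the scatter)), so the largest group among the four is the second best here and goes against the same rise.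

No measurement at hand accounts for why ethyl, tert-butyl and cyclohexylmethyl fall in this order. Still open, on these data alone, is whether hydrogen, a cyclopropyl ring, a longer chain such as n-propyl or an aminomethyl group on this carbon would fall below compound 3 or fit between the groups tested, and whether the order holds for the opposite configuration at this carbon.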